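Growth inhibition across three aryl variants

The source may report more compounds than this note shows. Statements on the series, on what has been measured and on what is new or still open speak of the compounds shown alone.

Compound 1 `Cc1ccc(CS(=O)(=O)/C(=C/c2sccc2C)C(=O)c2ccc(Cl)cc2)cc1`: 25000 nM
Compound 2 `Cc1ccc(CS(=O)(=O)/C(=C/c2c(O)cc(O)cc2O)C(=O)c2ccc(Cl)cc2)cc1`: > 100000 nM
Compound 3 `Cc1ccc(CS(=O)(=O)/C(=C/c2ccc(Cl)cc2)C(=O)c2ccc(Cl)cc2)cc1`: not yet measured

All values come from a functional assay on DU-145 cells (Homo sapiens) for inhibition, read by trypan blue exclusion, with a stated time of 96 h; a lower number here means a stronger inhibitor of growth, a higher number a weaker inhibitor of growth. Compound 2 stands at the limit of > 100000 nM in this assay, at which 1 of the 2 values shown sits, so its value is a limit and not a number. The next change is 4-chlorophenyl in place of 2,4,6-trihydroxyphenyl on a double-bonded chain carbon bound to a double-bonded chain carbon. For the measured compounds named here, one measured step bears on it, since 2,4,6-trihydroxyphenyl also entered there: an at least 4.0-fold higher number from compound 1 to compound 2 (0.60 log units; beyond the scatter). A move back towards a lower number, at least modest in size, is therefore expected, though that step gives only a bound. The expected step is an at least 6.6-fold lower number from compound 2 to compound 3 (0.82 log units; beyond the scatter). For compound 3 the estimate is 15000 nM, with an expected range of 3000 nM to 70000 nM.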

Compound 3, concentration for 50% growth inhibition: 25000 nM
Compound 3: middle estimate off by 1.7-fold (0.22 log units), on the low side; measured number inside the range.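

In this assay, this place on the double-bonded chain carbon does not separate a 4-chlorophenyl from a 3-methylthiophen-2-yl: no change at the digits printed from compound 1 to compound 3 (within the scatter). Only 2,4,6-trihydroxyphenyl stands apart among the three, with an at least 4.0-fold lower number from compound 2 to compound 3 (0.60 log units; beyond the scatter). Compound 2 gives > 100000 nM, which is a limit of the assay and not a number.

Which of the hydroxy groups of compound 2 carries this step stays open. Also open, on these data alone, is how a phenyl bearing an amine or a carboxylic acid would read at this place, and whether any group here gives a number clearly lower than those of compound 1 and compound 3.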